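Chloro to hydrogen in two benzyl-linked pairs

The source may report more compounds than this note shows. Statements on the series, on what has been measured and on what is new or still open speak of the compounds shown alone.

Measured compounds in a functional assay on U-251 cells (Homo sapiens) for cytotoxicity, read by sulforhodamine B assay, with a stated time of 48 h; on this read-out lower numbers stand for higher toxicity in this test and higher numbers for lower toxicity in this test:
- compound 1, `ClCc1ccccc1Cn1cnc2c(Cl)nc(Cl)nc21`: 4570 nM
- compound 2, `ClCc1ccccc1Cn1cnc2c(Cl)ncnc21`: 61700 nM
- compound 3, `ClCc1ccc(Cn2cnc3nc(Cl)nc(Cl)c32)cc1`: 5750 nM

Compound 1 and compound 2 differ in one place, (hydrogen in place of chloro on an aromatic carbon). This change made a large step: a 14-fold higher number from compound 1 to compound 2 (1.13 log units; beyond the scatter).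

Compound 3 carries the same atoms as compound 1, joined differently; the difference between the two cores is not broken down here. In this assay compound 3 gives 5750 nM, and against compound 1 its number sits within the usual scatter, so no order is drawn from the pair. Against compound 2 the number of compound 3 is clearly lower, beyond the scatter.

Compound 4, `ClCc1ccc(Cn2cnc3ncnc(Cl)c32)cc1`, is not yet measured. It differs from compound 3 in one place, (hydrogen in place of chloro on an aromatic carbon). The place is described word for word as in the pair of compound 1 and compound 2, so this is the same change, seen twice among the compounds here. The expectation for compound 4 rests on that one earlier pair alone: because a 14-fold higher number from compound 1 to compound 2 (1.13 log units; beyond the scatter) was large and beyond the scatter, a step of similar size is expected here, a 12-fold higher number from compound 3 to compound 4 (1.09 log units; beyond the scatter). Going by the values given here, with only one precedent, the range around the estimate is kept wide. In this assay compound 4 is expected to give about 70000 nM, with 25000 nM and 200000 nM as the ends of the expected range.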

Compound 4, concentration lethal to 50% of the cells: 4780 nM
The estimate for compound 4 lay 15-fold (1.17 log units) above the measured number; the whole stated range lies above it.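

In this assay, hydrogen in place of chloro on an aromatic carbon gives a 1.2-fold lower number from compound 3 to compound 4 (0.08 log units; within the scatter), so no order is drawn between these two compounds and the change has no readable effect on this core. The change therefore does not carry over from one core to the other at a similar size, and the large step seen on the first core cannot serve as a guide for the second: the same change on two cores in this assay, a 14-fold higher number (1.13 log units; beyond the scatter) from compound 1 to compound 2 and a 1.2-fold lower number (0.08 log units; within the scatter) from compound 3 to compound 4, 16-fold (1.21 log units) apart, beyond the scatter of two such steps. This shows that in this series the size of the step depends on the core carrying the change, but it does not show which difference between the two cores is responsible, and two pairs give no rule for predicting the step on a further core.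

Still open, from the compounds shown here alone, is how an amine or a methoxy group on the same aromatic carbon would read on either core, and whether the two cores would again part as they do for hydrogen. Also open, going by these compounds, is how a hydroxymethyl group in place of the chloromethyl group, present in all four compounds, would read in this assay.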